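The compounds below may be only part of what the source reports. "The series", "measured", "known", "first", "only" and "open" are said of these compounds alone.

Compound 1 `C[C@@H]1CN(c2nnc(Cc3ccccc3)c3ccccc23)CCN1c1ccc(C(F)(F)F)cn1`: 30000 nM
Compound 2 `C[C@@H]1CN(c2nnc(Cc3ccccc3)c3cc(Cl)ccc23)CCN1c1ccc(C#N)cn1`: 2300 nM
Compound 3 `C[C@@H]1CN(c2nnc(Cc3ccccc3)c3ccc(Cl)cc23)CCN1c1ccc(C#N)cn1`: 210 nM

In an assay on Sf9 cells for inhibition of sphingosine-1-phosphate lyase 1 (Homo sapiens), with a stated time of 1 h (a higher number here means a weaker inhibitor, a lower number a stronger inhibitor), compound 2 stands second highest of the three numbers. Compound 3 gives 210 nM, a lower number beyond the scatter, and compound 1 gives 30000 nM, a higher number beyond the scatter. Compound 4 `C[C@@H]1CN(c2nnc(Cc3ccccc3)c3cc(C#N)ccc23)CCN1c1ccc(C#N)cn1` differs from compound 2 in one place: cyano in place of chloro on an aromatic carbon. Going by the values given here, no measured pair shows this exchange, so the expected step from compound 2 to compound 4 is a 1.1-fold higher number from compound 2 to compound 4 (0.04 log units; within the scatter), small and not clearly beyond the scatter in either direction. Compound 4 is therefore expected to give about 2500 nM in this assay, with a range from 900 nM to 7000 nM.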

Compound 4, half-maximal inhibitory concentration: 1300 nM
Estimate against measurement, compound 4: 1.9-fold (0.28 log units) above, and the stated range covers the measured number.
By their numbers in this assay, from the lowest: compound 3; then compounds 4 and 2 (each within the scatter of the next); then compound 1.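

On this aromatic carbon, meta to a fused ring and para to a fused ring, cyano in place of chloro gives a 1.8-fold lower number from compound 2 to compound 4 (0.25 log units; within the scatter) in this assay. The position therefore takes either group, and the extra heavy atom and the hydrogen-bond acceptor that cyano brings cause no change beyond the scatter. No measurement available here explains this result.

From the compounds shown here alone, whether an amine, a carboxylic acid or a methoxy group would fit equally well on this carbon remains open. So does whether cyano and chloro would also match on other carbons of this ring.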